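A sec-butyl swap on compound 2

A few compounds are considered here, and "the series" means these few. Any claim that something is new, unique, unknown or untested is made for them only; others in the source may bear on it.

Measured in a functional assay on CCRF-CEM cells (Homo sapiens) for inhibition, with a stated time of 72 h; on this read-out lower numbers stand for stronger inhibition and higher numbers for weaker inhibition:
compound 1 `COC(=O)C[C@H](NC(=O)OC(C)(C)C)C(=O)N(Cc1ccccc1)C1(C(=O)NCc2ccccc2)CCN(C(=O)OC(C)(C)C)CC1`: 21000 nM
compound 2 `COC(=O)C[C@H](NC(=O)OC(C)(C)C)C(=O)N(Cc1ccc(F)cc1)C1(C(=O)NCc2ccccc2)CCN(Cc2ccccc2)CC1`: 16000 nM

Compound 2, at 16000 nM, lies within the usual scatter of compound 1, at 21000 nM, so these two numbers cannot be told apart. The two compounds differ in more than one place, and no single structural change can be read from them.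

Compound 3 `CCC(C)N(C(=O)[C@H](CC(=O)OC)NC(=O)OC(C)(C)C)C1(C(=O)NCc2ccccc2)CCN(Cc2ccccc2)CC1` has not yet been measured. It departs from compound 2 with sec-butyl in place of 4-fluorobenzyl on an amide-type nitrogen. Going by the values given here, no measured pair shows a change at this place, so the expectation is weakly anchored. No step beyond the scatter is expected in this assay, in either direction. The estimate amounts to a 1.3-fold higher number from compound 2 to compound 3 (0.10 log units; within the scatter), an expected step inside the scatter. For compound 3 the estimated value is 20000 nM, with an expected range of 8000 nM to 50000 nM.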

Compound 3, half-maximal inhibitory concentration: 19000 nM
The estimate for compound 3 lay 1.1-fold (0.02 log units) above the measured number; the range from low to high includes it.
By their numbers in this assay, from the lowest: compounds 2, 3 and 1 (each within the scatter of the next).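

In this assay, going by these compounds alone, this is the first comparison in which only the group on the amide-type nitrogen changes, and it gives a 1.2-fold higher number from compound 2 to compound 3 (0.07 log units; within the scatter). Within this pair, 4-fluorobenzyl, with its aromatic ring and fluorine, can give way to the smaller, ringless sec-butyl with no change that this read-out can resolve, so neither the ring nor the fluorine is shown to matter here. No independent evidence is available to explain why the two groups read alike.

On these data alone, it remains open whether any group at this nitrogen can move the number beyond the scatter, for example an amine, a carboxylic acid or a longer chain. As far as these compounds go, it is also open whether sec-butyl and 4-fluorobenzyl would still read alike with a different group elsewhere on the shared core.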